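This account rests on a few compounds, and the source may have more. Where it says the series, first, only, none or still open, it means among the compounds named here.

Measured so far:
compound 1, `CC(C)CCn1nc(-c2cccs2)c(O)c(C2=NS(=O)(=O)c3cc(N(C)S(C)(=O)=O)ccc3N2)c1=O`: > 33000 nM
compound 2, `CCCC(C)n1nc(-c2cccs2)c(O)c(C2=NS(=O)(=O)c3cc(NS(C)(=O)=O)ccc3N2)c1=O`: > 33000 nM

In an ADME assay on Huh-7 cells (Homo sapiens) for cytotoxicity, with a stated time of 72 h (a lower number here means that less compound is tolerated, a higher number that more compound is tolerated), compound 2 gives > 33000 nM, and this is a limit of the assay rather than a number. Compound 1 gives > 33000 nM in this assay, again a limit. So compound 2 stands where every value shown stands, at the limit of > 33000 nM in this assay, at which 2 of the 2 values shown sit; no compound here has a measured number.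

Compound 3, `CS(=O)(=O)Nc1ccc2c(c1)S(=O)(=O)N=C(c1c(O)c(-c3cccs3)nn(CCC3CCC3)c1=O)N2`, is the next compound to be measured in this assay. It differs from compound 2 in a single place: 2-cyclobutylethyl in place of 1-methylbutyl on an aromatic nitrogen.

Among the compounds with values here, no step between two measured compounds exists here, so there is no measured guide for this change. The expectation is a step that the limit leaves unreadable from compound 2 to compound 3, that is, no change beyond the scatter, with the result most likely being another limit. Compound 3 is expected to give about 40000 nM in this assay, within a range from 20000 nM to 100000 nM.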

Compound 3, half-maximal cytotoxic concentration: > 1000 nM
Compound 3 was reported as a limit (the forecaster's own chance of this, stated with the estimate: 85%); the middle value lies beyond the limit too.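

Compound 2 and compound 3 are both reported only as limits in this assay, not as numbers, so the step between them cannot be read. The compounds shown leave open whether 2-cyclobutylethyl in place of 1-methylbutyl changes the tolerated concentration at all.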